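This account rests on a few compounds, and the source may have more. Where it says the series, first, only, none or still open, it means among the compounds named here.

Compound 2 `CCC(C)CCn1nc(-c2cccs2)c(O)c(C2=NS(=O)(=O)c3cc(OCC(N)=O)ccc3N2)c1=O` has been tested in an in vitro ADME assay on microsomes from liver (Homo sapiens) for metabolic stability (a higher number here means that the compound lasts longer, a lower number that the compound disappears faster), where compound 2 gives 0.417 h. Its only companion so far is compound 1 `CC(C)(C)CCn1nc(-c2cccs2)c(O)c(C2=NS(=O)(=O)c3cc(OCC(N)=O)ccc3N2)c1=O`, which in this assay gives 0.35 h; the two numbers lie within the scatter of each other, as the step of a 1.2-fold higher number from compound 1 to compound 2 (0.08 log units; within the scatter) shows, so neither can be called longer-lived on this evidence.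

Compound 3 `NC(=O)COc1ccc2c(c1)S(=O)(=O)N=C(c1c(O)c(-c3cccs3)nn(CC3CCCCC3)c1=O)N2` has not yet been measured. It differs from compound 2 by cyclohexyl in place of 2-methylbutyl on a saturated chain carbon bound to an aromatic nitrogen. For the measured compounds named here, the one measured step bears on the same part of the molecule, the chain attached to the aromatic nitrogen, and it stayed within the scatter; there is no measured step showing what closing that chain into a ring does. On this basis the expected step is a 1.1-fold higher number from compound 2 to compound 3 (0.03 log units; within the scatter), with no change beyond the scatter foreseen. Compound 3 is therefore estimated at about 0.45 h, in the range 0.2 h to 1 h.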

Compound 3, half-life: > 1 h
Compound 3: no number, only a limit (the forecaster's own chance of this, stated with the estimate: 5%); middle value at least 2.2-fold (0.34 log units) from the limit.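

The readings in this assay had so far shown only two open branched chains on the aromatic nitrogen, with values within the scatter of each other, so this position seemed not to matter. A ring changes that picture: cyclohexyl in place of 2-methylbutyl gives an at least 2.3-fold higher number from compound 2 to compound 3 (0.37 log units; beyond the scatter) and cyclohexyl in place of neopentyl gives an at least 2.8-fold higher number from compound 1 to compound 3 (0.45 log units; beyond the scatter) so the chain at this position can move the half-life beyond the scatter. For compound 3 the result (> 1 h) is a limit of the assay and not a number, so the full size of both steps cannot be read: the limit of > 1 h in this assay, at which 1 of the 3 values shown sits.

As far as these compounds go, it remains open whether the ring itself matters, or whether its size does. A smaller carbon ring such as cyclopentyl, a six-membered ring containing oxygen, or a longer open chain could each help to separate these possibilities.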